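This account rests on a few compounds, and the source may have more. Where it says the series, first, only, none or still open, it means among the compounds named here.

In a physicochemical assay for solubility (on this read-out higher numbers stand for higher solubility and lower numbers for lower solubility), three compounds have been measured:

- Compound 1 `C[C@H]1C(=O)N(C)C=Cc2cc(C(CO)CO)ccc21`: >= 209 ug/mL, a limit
- Compound 2 `CCS(=O)(=O)c1ccc2c(c1)C(c1cnn(C)c1)=CN(C)C(=O)[C@@H]2C`: >= 222 ug/mL, a limit
- Compound 3 `CCOc1ccc2c(c1)C(c1cnn(C)c1)=CN(C)C(=O)[C@@H]2C`: 143 ug/mL

For the measured compounds named here, compound 3 holds the only number here, as the other two values are limits. Compound 4 `C[C@H]1C(=O)N(C)C=C(c2cnn(C)c2)c2cc(C(CO)CO)ccc21` differs from compound 3 by one change: 2-hydroxy-1-(hydroxymethyl)ethyl in place of ethoxy on an aromatic carbon. Going by the values given here, the only measured step at this place is an at least 1.5-fold lower number from compound 2 to compound 3 (0.19 log units; that floor lies within the scatter). Compound 1 carries the same incoming group, and its >= 209 ug/mL is a limit. Going by that step and that limit, a modest rise in this assay is expected, possibly reported only as a limit. The expected change is a 1.5-fold higher number from compound 3 to compound 4 (0.17 log units; within the scatter). For compound 4 the estimate is 210 ug/mL, with an expected range of 120 ug/mL to 320 ug/mL.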

Compound 4, solubility: >= 208 ug/mL
Compound 4 was reported as a limit; the forecaster's own chance of this, stated with the estimate: 55%; the middle value lies beyond the limit too.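

In this assay, for the compounds shown here, 2-hydroxy-1-(hydroxymethyl)ethyl in place of ethoxy on this aromatic carbon gives an at least 1.4-fold higher number from compound 3 to compound 4 (0.16 log units; that floor lies within the scatter), the first reading for this group at this position with 1-methyl-1H-pyrazol-4-yl present. Compound 4 gives a limit rather than a number, so this step has only a floor. The steps to compound 4 from compound 1 and from compound 2 cannot be read, as both ends of each are limits.

From the compounds shown here alone, how far compound 4 lies past its limit stays open. So does whether an amine or a carboxylic acid on this aromatic carbon would give a number rather than a limit.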